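The source may report more compounds than this note shows. Statements on the series, on what has been measured and on what is new or still open speak of the compounds shown alone.

Measured compounds in a physicochemical assay for lipophilicity, read by LC-MS, in phosphate buffer, measured as octanol-water partition, with a stated time of 30 min, at pH 7.4, tested at 200 mM; on this read-out lower numbers stand for lower lipophilicity and higher numbers for higher lipophilicity:

Compound 1 `Cn1c(COc2cccc(C(=O)O)c2)nc2ccc(Oc3cccc(Cl)n3)cc21` gives 1.2.
Compound 2 `Cn1c(COc2cccc(C(=O)O)c2)nc2ccc(Oc3ncccc3F)cc21` gives 0.6.
Compound 3 `Cn1c(COc2cccc(C(=O)O)c2)nc2ccc(Oc3ncc(Cl)cc3Cl)cc21` gives 1.9.

Compound 3 stands highest of the three in this assay. Its nearest neighbour is compound 1, reached by a number 0.70 log units higher from compound 1 to compound 3 (beyond the scatter); compound 2 lies furthest away, and the move a number 1.30 log units higher from compound 2 to compound 3 (beyond the scatter) is the largest step among these compounds. The change a number 0.60 log units lower from compound 1 to compound 2 (beyond the scatter) shows that swapping one halogen pattern for another on the same oxygen-linked ring can move the number either way.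

Compound 4 `Cc1cc(Cl)cnc1Oc1ccc2nc(COc3cccc(C(=O)O)c3)n(C)c2c1` is made from compound 3 by methyl in place of chloro on an aromatic carbon. Among the measured compounds shown here, none of the measured steps tests a chloro-to-methyl swap; each of them exchanges one halogenated pyridinyl ring for another with a different halogen count and position. For the measured compounds named here, they show that this part of the molecule can shift the number well beyond the scatter, but they give no direct reading for the single change at hand.

Going by the values given here, with no matching precedent, the expected step of a number 0.20 log units lower from compound 3 to compound 4 (within the scatter) is small and at the edge of the scatter, slightly downward. Compound 4 is therefore estimated at 1.7, with a likely range from 1.2 to 2.2.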

Compound 4, distribution coefficient: 1.8
Compound 4: middle estimate off by 0.10 log units, on the low side, within the range that was stated.
By their numbers in this assay, from the lowest: compound 2; then compound 1; then compounds 4 and 3 (each within the scatter of the next).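

In this assay, among the compounds shown here, the swap of chloro for methyl, on an aromatic carbon ortho to a large group and two atoms from the ring nitrogen, now has a direct reading: the step of a number 0.10 log units lower from compound 3 to compound 4 (within the scatter) leaves the two groups indistinguishable at this place, whereas the earlier steps each changed the halogen count or position and moved the number beyond the scatter. The 5-chloro-3-methylpyridin-2-yl ring therefore stands apart from the two other rings much as 3,5-dichloropyridin-2-yl does, with the large step of a number 1.20 log units higher from compound 2 to compound 4 (beyond the scatter) and the modest step of a number 0.60 log units higher from compound 1 to compound 4 (beyond the scatter) on record in this assay for the same comparison. Nothing shown gives a reason why this swap leaves the number where it was.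

This is a single pair, so it cannot say whether methyl and chloro would read alike on another aromatic carbon of the same ring, or with the remaining chloro group gone. From the compounds shown here alone, how a different group at this place, such as methoxy, an amine or a longer chain like propyl, would move the number remains open.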